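The source may report more compounds than this note shows. Statements on the series, on what has been measured and on what is new or still open speak of the compounds shown alone.

Compound 1 `NS(=O)(=O)c1cccc(-c2nc(C(c3ccc(F)cc3)c3ccc(F)cc3)sc2CC(=O)O)c1`: 140 nM
Compound 2 `O=C(O)Cc1sc(C(c2ccc(F)cc2)c2ccc(F)cc2)nc1-c1ccco1`: 18 nM
Compound 3 `O=C(O)Cc1sc(C(c2ccc(F)cc2)c2ccc(F)cc2)nc1-c1ccncc1`: 5.3 nM

These three compounds share one core and differ only in the aromatic group attached to it. In an in vitro assay on HEK385-7 cells for displacement of a labelled ligand from prostaglandin D2 receptor 2 (Homo sapiens) (a higher number here means a weaker inhibitor, a lower number a stronger inhibitor), compound 3 gives the lowest of the three numbers. Its nearest neighbour is compound 2, and the step of a 3.4-fold lower number from compound 2 to compound 3 (0.53 log units; beyond the scatter) lies beyond the scatter; the step of a 26-fold lower number from compound 1 to compound 3 (1.42 log units; beyond the scatter) is larger still. The remaining step, a 7.8-fold lower number from compound 1 to compound 2 (0.89 log units; beyond the scatter), separates the two weaker compounds from each other.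

Compound 4 `Nc1cc(-c2nc(C(c3ccc(F)cc3)c3ccc(F)cc3)sc2CC(=O)O)cc(F)n1` has not yet been measured. It differs from compound 3 in one place: 2-amino-6-fluoropyridin-4-yl in place of pyridin-4-yl on an aromatic carbon. The six-membered ring with its single ring nitrogen is kept; an amino group and a fluorine are added to it.

The measured steps all exchange one whole aromatic group for another, and each moved this assay beyond the scatter. Going by the values given here, no measured step adds groups to a ring that is otherwise kept, so none bears directly on this change. With nothing shown to the contrary, a step in this assay of no more than modest size in either direction is expected, a 1.1-fold higher number from compound 3 to compound 4 (0.05 log units; within the scatter). Compound 4 is therefore estimated at 6 nM, within the range 1.5 nM to 25 nM.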

Compound 4, half-maximal inhibitory concentration: 220 nM
Compound 4: middle estimate off by 37-fold (1.56 log units), on the low side, and the stated range ends below it.
By their numbers in this assay, from the lowest: compound 3; then compound 2; then compounds 1 and 4 (each within the scatter of the next).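

Keeping the six-membered ring with its single ring nitrogen does not keep the reading in this assay: adding an amino group and a fluorine to that ring gives a 42-fold higher number from compound 3 to compound 4 (1.62 log units; beyond the scatter). At this position, on the aromatic carbon next to the ring nitrogen of the five-membered ring, what is attached to the aromatic group therefore counts as well as which aromatic group it is, and the added groups cancel the advantage of the pyridine-type ring over the furan-2-yl group, with a 12-fold higher number from compound 2 to compound 4 (1.09 log units; beyond the scatter), while a 1.6-fold higher number from compound 1 to compound 4 (0.20 log units; within the scatter) leaves compound 4 level with the 3-sulfamoylphenyl compound. No measurement shown here explains why these additions have so large an effect.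

The amino group and the fluorine entered together, so the compounds shown cannot tell how much of the step belongs to each, and a pyridin-4-yl ring carrying the amino group alone or the fluorine alone would separate them. As far as these compounds go, it also stays open whether a smaller addition such as a methyl group or a chlorine on the same ring would be tolerated in this assay.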